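The compounds below may be only part of what the source reports. "The series", "measured", "known", "first", "only" and "open" are said of these compounds alone.

The measured compounds stand as follows.

Compound 1 `C=CC1=C(C(=O)NCc2ccc(Cl)cc2)C(c2ccc(F)cc2)OC1` gives > 100000 nM in a functional assay on SW480 cells (Homo sapiens) for cytotoxicity, read by MTT assay, with a stated time of 24 h (a higher number here means a weaker inhibitor, a lower number a stronger inhibitor), and this is a limit of the assay rather than a number.
Compound 2 `C=CC1=C(C(=O)Nc2ccccc2)C(c2ccc(Cl)c(Cl)c2)OC1` gives > 100000 nM in this assay, again only a limit.
Compound 3 `C=CC1=C(C(=O)Nc2ccccc2)C(c2ccc(OC)cc2)OC1` gives > 100000 nM in this assay, likewise a limit.

Compound 1 therefore stands nowhere in particular on a scale: its result is a limit, and the two further results are limits as well, so that the limit of > 100000 nM in this assay, at which 3 of the 3 values shown sit, sums up the whole picture. Among the measured compounds shown here, the one step that can be drawn between measured compounds, a step that the two limits leave unreadable from compound 2 to compound 3, cannot be read in size or direction because the limit of > 100000 nM in this assay, at which 3 of the 3 values shown sit, holds for both of its ends.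

The unmeasured compound 4 `C=CC1=C(C(=O)NC2CCCCC2)C(c2ccc(F)cc2)OC1` differs from compound 1 in one place: cyclohexyl in place of 4-chlorobenzyl on an amide-type nitrogen. No measured step touches the amide-type nitrogen; the only shown step concerns the saturated ring carbon and is itself unreadable, so nothing measured bears directly on this change. All three shown results sit at the same limit, and compound 4 shares the core and the 4-fluorophenyl group of compound 1. Compound 4 is therefore expected to give about 150000 nM in this assay, within an estimated range from 50000 nM to 500000 nM, most probably reported again as a limit. The step that this estimate implies, a step that the limit leaves unreadable from compound 1 to compound 4, is expected to fall within the scatter.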

Compound 4, half-maximal inhibitory concentration: > 100000 nM
Compound 4 gave a limit, no number; the forecaster's own chance of this, stated with the estimate: 85%; the middle value does not contradict the limit.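

Compound 4, like compound 1, gives only a limit, so no step can be read for cyclohexyl in place of 4-chlorobenzyl on the amide-type nitrogen, because the results offer no number to compare: the limit of > 100000 nM in this assay, at which 4 of the 4 values shown sit.

The compounds shown leave open whether any group on the shared core affects the result in this assay.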